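This account rests on a few compounds, and the source may have more. Where it says the series, first, only, none or still open, it means among the compounds named here.

Compound 2 `CCOC(=O)c1c(C)oc2nc(Nc3cccc(C)c3)nc(N3CCN(C)CC3)c12` was tested in a functional assay on A549 cells (Homo sapiens) for cytotoxicity, read by MTT assay, with a stated time of 48 h (a higher number here means a weaker inhibitor, a lower number a stronger inhibitor), where compound 2 gives 5500 nM. Of the two numbers available, that of compound 2 is the lowest, and its nearest neighbour is compound 1 `CCCCNc1nc(Nc2cccc(C)c2)nc2oc(C)c(C(=O)OCC)c12`, which in this assay gives 9000 nM. Among the compounds with values here, the one measured step between them, a 1.6-fold lower number from compound 1 to compound 2 (0.21 log units; within the scatter), exchanges one amine substituent on the shared core for another, and the numbers do not separate beyond the scatter. Compound 3 `CCOC(=O)c1c(C)oc2nc(Nc3cccc(C)c3)nc(N(CC)CC)c12` has not yet been measured in this assay. It differs from compound 2 in a single place: diethylamino in place of 4-methylpiperazin-1-yl on an aromatic carbon. This is once more an exchange of the amine substituent at the same place on the shared core. Within the data shown here, the only measured step that bears on it is a 1.6-fold lower number from compound 1 to compound 2 (0.21 log units; within the scatter), which was within the scatter, so no step beyond the scatter is expected here either. For compound 3 the expected step is a 1.1-fold higher number from compound 2 to compound 3 (0.04 log units; within the scatter). Compound 3 is therefore estimated at 6000 nM, with a range from 2500 nM to 15000 nM.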

Compound 3, half-maximal inhibitory concentration: 8800 nM
Compound 3: the middle estimate sits 1.5-fold (0.17 log units) below what was measured, within the range that was stated.
By their numbers in this assay, from the lowest: compounds 2, 3 and 1 (each within the scatter of the next).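

In this assay, the exchange of 4-methylpiperazin-1-yl for diethylamino gives a 1.6-fold higher number from compound 2 to compound 3 (0.20 log units; within the scatter), so losing the six-membered non-aromatic ring and its second nitrogen at this aromatic carbon does not separate the numbers beyond the scatter. Within the data shown here, the exchange of butylamino for diethylamino gives a 1.0-fold lower number from compound 1 to compound 3 (0.01 log units; within the scatter), which likewise stays within the scatter, so all three amine substituents, one cyclic and two open-chain, now lie within the scatter of one another at this place, a wider reading than the single earlier step could give. No independent measurement bears on this result, so the flat numbers cannot be explained from the data shown.

The compounds shown leave open whether any group at this place would move the number beyond the scatter, for instance morpholine, a substituted aniline or an amine with a chain longer than butyl. They also leave open whether changes elsewhere on the shared core matter more, such as a carboxylic acid or an amide in place of the ethyl ester, or another group in place of the (3-methylphenyl)amino group.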